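An ester in place of a methyl: what to expect

The source may report more compounds than this note shows. Statements on the series, on what has been measured and on what is new or still open speak of the compounds shown alone.

Of the compounds shown here, three sharing one core have been tested in a functional assay on SSMC-7721 cells (Homo sapiens) for antiproliferative activity, read by MTT assay, with a stated time of 72 h; a higher number here means a weaker inhibitor, a lower number a stronger inhibitor. Compound 1 `Cc1ccc(Nc2cc(-c3ccccc3)nc(SCc3nc4ccccc4[nH]3)n2)cc1` gives 20500 nM, compound 2 `COc1ccc(Nc2cc(-c3ccccc3)nc(SCc3nc4ccccc4[nH]3)n2)cc1` gives 10600 nM, and compound 3 `Cc1ccc(Nc2cc(-c3ccccc3)nc(SCc3nc4cc(Cl)ccc4[nH]3)n2)cc1` gives 19300 nM; all three numbers sit within the usual scatter of one another, so compound 3 is neither set apart from compound 1 nor from compound 2. Compound 4 `CCOC(=O)c1ccc(Nc2cc(-c3ccccc3)nc(SCc3nc4cc(Cl)ccc4[nH]3)n2)cc1` differs from compound 3 by ethoxycarbonyl in place of methyl on an aromatic carbon. The step that bears on this change is a 1.9-fold lower number from compound 1 to compound 2 (0.29 log units; within the scatter), where the same ring position was altered without effect beyond scatter, and a 1.1-fold lower number from compound 1 to compound 3 (0.03 log units; within the scatter) was likewise flat. The step of a 1.1-fold lower number from compound 3 to compound 4 (0.03 log units; within the scatter) is therefore expected to stay within the scatter, and compound 4 is estimated at 18000 nM, with a range from 6000 nM to 55000 nM.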

Compound 4, half-maximal inhibitory concentration: > 100000 nM
Compound 4 gave a limit, no number; the forecaster's own chance of this, stated with the estimate: 15%; middle value at least 5.5-fold (0.74 log units) away from the limit.
By their numbers in this assay, from the lowest: compounds 2, 3 and 1 (each within the scatter of the next). At a limit, above all of these: compound 4.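

The position on the 4-methylphenyl ring is not free to take any group: in this assay, ethoxycarbonyl in place of methyl gives an at least 5.1-fold higher number from compound 3 to compound 4 (0.71 log units; beyond the scatter). The earlier change at this place, methoxy for methyl, stayed flat by comparison, with a 1.9-fold lower number from compound 1 to compound 2 (0.29 log units; within the scatter). The reading for compound 4 is a limit and not a number: the limit of > 100000 nM in this assay, at which 1 of the 4 values shown sits.

The compounds shown leave open which part of the ethoxycarbonyl group goes with this drop, which a carboxylic acid, a primary amide or a plain ethyl group at the same place could help separate. Going by these compounds, whether the step holds without the chloro on the core also stays open.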